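Hydrazone aryl variation on the shared core of compound 1

This account rests on a few compounds, and the source may have more. Where it says the series, first, only, none or still open, it means among the compounds named here.

Measured compounds:
- compound 1 `Cc1c(C(=O)N/N=C\c2ccc(O)cc2)oc2cccc(O)c12`: 21700 nM
- compound 2 `Cc1c(C(=O)N/N=C\c2cc(O)ccc2O)oc2cccc(O)c12`: 95500 nM
- compound 3 `Cc1c(C(=O)N/N=C\c2cccc(Br)c2O)oc2cccc(O)c12`: 16600 nM

In a functional assay on PC-3 cells (Homo sapiens) for inhibition (a lower number here means a stronger inhibitor, a higher number a weaker inhibitor), compound 1 stands second highest of the three numbers; compound 3 lies nearest, a 1.3-fold lower number from compound 1 to compound 3 (0.12 log units; within the scatter), and compound 2 furthest, a 4.4-fold higher number from compound 1 to compound 2 (0.64 log units; beyond the scatter). Between compounds 2 and 3 the step is a 5.8-fold lower number from compound 2 to compound 3 (0.76 log units; beyond the scatter).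

Compound 4 `Cc1c(C(=O)N/N=C\c2ccco2)oc2cccc(O)c12` is not yet measured. It differs from compound 1 as follows: furan-2-yl in place of 4-hydroxyphenyl on a carbon with a double bond to nitrogen. Among the compounds with values here, no measured step removes the phenol or exchanges the ring for a five-membered one; the two steps from compound 1 bear only loosely. Adding a hydroxyl gave a weaker number, while bromine with a shifted hydroxyl stayed within the scatter. Dropping the hydroxyl and shrinking the ring is therefore expected to give a small shift, most likely toward a weaker number, as a 1.4-fold higher number from compound 1 to compound 4 (0.14 log units; within the scatter). Compound 4 is estimated at 30000 nM, with a range of 9000 nM to 90000 nM.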

Compound 4, half-maximal inhibitory concentration: >= 40000 nM
Compound 4: only a limit was reported; the forecaster's own chance of this, stated with the estimate: 15%; middle value at least 1.3-fold (0.12 log units) from the limit.
By their numbers in this assay, from the lowest: compounds 3 and 1 (each within the scatter of the next); then compound 2.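

In this assay, compound 4 is reported only as a limit: the limit of >= 40000 nM in this assay, at which 1 of the 4 values shown sits.

Furan-2-yl is the first group on this carbon with a double bond to nitrogen that has no hydroxyl and a five-membered ring, and the readable steps differ in weight: an at least 1.8-fold higher number from compound 1 to compound 4 (0.26 log units; that floor lies within the scatter) has a floor that stays within the scatter, whereas an at least 2.4-fold higher number from compound 3 to compound 4 (0.38 log units; beyond the scatter) is beyond it. The step between compound 2 and compound 4 cannot be read.

The loss of the hydroxyl and the change of ring size occur together in compound 4, so the compounds shown do not separate them, and the true size of both readable steps stays open. Also open, going by these compounds, is how a plain phenyl, or a phenyl carrying an amine, would read at this place.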